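Shortening a Side Chain: From Compound 3 to Compound 4

A few compounds are considered here, and "the series" means these few. Any claim that something is new, unique, unknown or untested is made for them only; others in the source may bear on it.

Compound 3 `CCCC[C@H](N)C(=O)N[C@@H](CC(C)C)B(O)O` was tested in an ADME assay on FSCLL cells (Homo sapiens) for cytotoxicity, read by MTT assay, with a stated time of 24 h (on this read-out lower numbers stand for higher toxicity in this test and higher numbers for lower toxicity in this test), where compound 3 gives 950 nM. Among the three compounds measured, compound 3 stands second highest: compound 1 `CC(C)C[C@H](NC(=O)CN)B(O)O` gives 670 nM in this assay, and compound 2 `CC(C)C[C@H](NC(=O)[C@@H](N)CO)B(O)O` gives 1700 nM. The step of a 1.4-fold higher number from compound 1 to compound 3 (0.15 log units; within the scatter) is small, while the step of a 2.5-fold higher number from compound 1 to compound 2 (0.40 log units; beyond the scatter) is larger. Compound 4 `CC[C@H](N)C(=O)N[C@@H](CC(C)C)B(O)O` differs from compound 3 by hydrogen in place of ethyl on a saturated chain carbon, three bonds along the chain from an amine nitrogen and a carbonyl carbon. The step that bears most on this change is a 1.4-fold higher number from compound 1 to compound 3 (0.15 log units; within the scatter), which adds a chain at the same place without moving the number beyond the scatter, so shortening that chain is expected to leave the number roughly in place. Compound 4 is therefore expected to give 800 nM in this assay, estimated between 400 nM and 1600 nM, a change of a 1.2-fold lower number from compound 3 to compound 4 (0.07 log units; within the scatter).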

Compound 4, half-maximal cytotoxic concentration: 1500 nM
Compound 4: the middle estimate sits 1.9-fold (0.27 log units) below what was measured; measured number inside the range.
By their numbers in this assay, from the lowest: compounds 1, 3, 4 and 2 (each within the scatter of the next, the first and the last beyond it).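

With ethyl at this place, the gap from hydrogen passes the scatter (a 2.2-fold higher number from compound 1 to compound 4 (0.35 log units; beyond the scatter)), which butyl in compound 3 did not do, and cutting butyl back to ethyl stays within it (a 1.6-fold higher number from compound 3 to compound 4 (0.20 log units; within the scatter)). Methyl in place of hydroxy also stays within the scatter (a 1.1-fold lower number from compound 2 to compound 4 (0.05 log units; within the scatter)), so the ethyl and hydroxymethyl chains cannot be told apart here. Nothing available explains these steps.

Still open, as far as these compounds go, is how a methyl or propyl chain, or an amine at the end of the chain, would read at this place.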